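A few compounds are considered here, and "the series" means these few. Any claim that something is new, unique, unknown or untested is made for them only; others in the source may bear on it.

Measured in a functional assay on U-251 cells (Homo sapiens) for antiproliferative activity, read by MTT assay, with a stated time of 24 h; a higher number here means a weaker inhibitor, a lower number a stronger inhibitor:
- Compound 1 `COc1cc(OC)c(-c2coc3cc(OCC=C(C)C)ccc3c2=O)cc1OC`: 3500 nM
- Compound 2 `COc1cc(OC)c(-c2coc3cc(OCC(=O)c4cccc(C(F)(F)F)c4)ccc3c2=O)cc1OC`: > 10000 nM

For compound 2, > 10000 nM is a limit and not a number. Compound 3 `COc1cc(OC)c(-c2coc3cc(OCc4ccccc4F)ccc3c2=O)cc1OC` has 2-fluorophenyl in place of (3-(trifluoromethyl)phenyl)carbonyl on a saturated chain carbon bound to an oxygen on an aromatic ring. Among the compounds with values here, one measured step bears on this, the step that brought that group in, an at least 2.8-fold higher number from compound 1 to compound 2 (0.45 log units; beyond the scatter). With the group gone, compound 3 is expected to lie nearer compound 1, which gives 3500 nM. The expected change in this assay is an at least 2.0-fold lower number from compound 2 to compound 3 (0.30 log units; that floor lies within the scatter), towards a stronger inhibitor. Compound 3 is estimated at 5000 nM, with an expected range of 1500 nM to 10000 nM.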

Compound 3, half-maximal inhibitory concentration: 2890 nM
Estimate against measurement, compound 3: 1.7-fold (0.24 log units) above; the measured number falls inside the stated range.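

With 2-fluorophenyl on a saturated chain carbon bound to an oxygen on an aromatic ring, the activity lost with (3-(trifluoromethyl)phenyl)carbonyl returns in this assay: an at least 3.4-fold lower number from compound 2 to compound 3 (0.53 log units; beyond the scatter). An aromatic ring can therefore stand at this position in place of 2-methylprop-1-en-1-yl with no change beyond the scatter, a 1.2-fold lower number from compound 1 to compound 3 (0.08 log units; within the scatter). The value of compound 2 is a limit and not a number: the limit of > 10000 nM in this assay, at which 1 of the 3 values shown sits.

The compounds shown do not separate the carbonyl from the trifluoromethyl in compound 2. On these data alone, how an amine or a carboxylic acid at this position would fare remains open.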